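A few compounds are considered here, and "the series" means these few. Any claim that something is new, unique, unknown or untested is made for them only; others in the source may bear on it.

Measured in an ADME assay on S9 fraction from liver (Mus musculus, strain CD-1) for metabolic stability, read by LC-MS, using NADPH, with stated times of 5 min and 60 min, tested at 5 uM; a lower number here means that less of the compound is left, a higher number that more of the compound is left:
compound 1 `COc1cc(C2CN(C(=O)c3cc(OC[C@H](O)CO)ccn3)C2)ccc1OCc1ccc(C2CC2)cc1`: 67%
compound 2 `CCc1ccc(COc2ccc(C3CN(C(=O)c4cc(COC[C@@H](O)CO)ccn4)C3)cc2OC)cc1`: 26%

Of these two numbers, compound 1 holds the higher at 67%, and compound 2 lies below it by a gap beyond the usual scatter of repeated measurements. Compound 3 `COc1cc(C2CN(C(=O)c3cc(COC[C@H](O)CO)ccn3)C2)ccc1OCc1ccc(C2CC2)cc1` has not yet been measured. It departs from compound 1 at one place, on an aromatic carbon of a six-membered aromatic ring with 1 nitrogen, opposite the ring nitrogen: (2,3-dihydroxypropoxy)methyl stands in place of 2,3-dihydroxypropoxy ((2,3-dihydroxypropoxy)methyl in place of 2,3-dihydroxypropoxy on an aromatic carbon). Among the compounds with values here, no pair of measured compounds shows this change alone, so its size cannot be read directly from the data. Compound 2 also carries (2,3-dihydroxypropoxy)methyl and gives 26%, which suggests a downward step in this assay. This is weak evidence from a single compound, so only part of the gap is expected to carry over. The expected change is a number 25 percentage points lower from compound 1 to compound 3 (beyond the scatter). For compound 3 the estimated value is 42%, with an expected range from 22% to 65%.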

Compound 3, percent of the compound remaining: 70%
Estimate against measurement, compound 3: 28 percentage points below, and the stated range ends below it.
By their numbers in this assay, from the lowest: compound 2; then compounds 1 and 3 (each within the scatter of the next).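

Seen alone on the core of compound 1, (2,3-dihydroxypropoxy)methyl in place of 2,3-dihydroxypropoxy, on an aromatic carbon opposite the ring nitrogen, gives in this assay a number 3 percentage points higher from compound 1 to compound 3 (within the scatter), so the two groups cannot be told apart by this read-out at this position on that core. The low number of compound 2, 26%, therefore cannot be taken as the mark of (2,3-dihydroxypropoxy)methyl, since compound 3 carries the same group and stands level with compound 1. Nothing measured here says why the two chains read alike.

Within the data shown here, what sets compound 2 apart stays unresolved, as it differs from compound 3 in more than one place and no step connects it to either of the other compounds. Also open, going by these compounds, is how far this position accepts other groups, for instance whether an amine, a carboxylic acid or a longer chain on the same aromatic carbon would leave as much of the compound remaining as the two diol chains do.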